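Adding a methylpiperazine to a weak growth inhibitor

The compounds below may be only part of what the source reports. "The series", "measured", "known", "first", "only" and "open" are said of these compounds alone.

Measured in a functional assay on MCF7 cells (Homo sapiens) for inhibition, read by CCK-8 assay, with a stated time of 48 h; a lower number here means a stronger inhibitor of growth, a higher number a weaker inhibitor of growth:
- Compound 1 `Cc1ccccc1Nc1nc(Nc2ccccc2)ncc1Cl`: > 100000 nM, a limit of the assay and not a number.
- Compound 2 `Cc1ccccc1Nc1nc(Nc2ccccn2)ncc1Cl`: 31400 nM.

Going by the values given here, compound 2, at 31400 nM, holds the only true number so far. For compound 1 the reading is only a limit: the limit of > 100000 nM in this assay, at which 1 of the 2 values shown sits. Among the compounds with values here, the single measured step, an at least 3.1-fold lower number from compound 1 to compound 2 (0.50 log units; beyond the scatter), lies beyond the scatter and is the only guide available.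

Compound 3 `Cc1ccccc1Nc1nc(Nc2ccc(N3CCN(C)CC3)cn2)ncc1Cl` keeps compound 2 intact except for one place, where 4-methylpiperazin-1-yl stands in place of hydrogen on an aromatic carbon of the pyridin-2-yl ring: 4-methylpiperazin-1-yl in place of hydrogen on an aromatic carbon. Within the data shown here, no measured step adds this group, so the guide is loose. Still, that same ring gave an at least 3.1-fold lower number from compound 1 to compound 2 (0.50 log units; beyond the scatter), so a further move to a lower number in this assay, of modest to large size, is expected. The expected change is a 6.3-fold lower number from compound 2 to compound 3 (0.80 log units; beyond the scatter). For compound 3 the estimated value is 5000 nM, with an expected range of 700 nM to 30000 nM.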

Compound 3, concentration for 50% growth inhibition: 5210 nM
Beside the measured number, compound 3's estimate is 1.0-fold (0.02 log units) below it, and the stated range covers the measured number.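

In this assay, the carbon two atoms from the ring nitrogen of the pyridin-2-yl ring accepts a large 4-methylpiperazin-1-yl group, and growth inhibition improves, with a 6.0-fold lower number from compound 2 to compound 3 (0.78 log units; beyond the scatter). This is also the first step with a true number at both ends, so its size can be read directly, whereas the earlier step starts from compound 1, whose reading is only a limit: the limit of > 100000 nM in this assay, at which 1 of the 3 values shown sits.

The values show the size of the change but not its cause. The compounds shown leave open how much of the group is needed: a piperazine without the methyl, a morpholine or a plain dimethylamino group would each test part of it. They also leave open what the same 4-methylpiperazin-1-yl group would do at another carbon of the pyridin-2-yl ring.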